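Efficacy around the benzylic carbon of the shared core

The source may report more compounds than this note shows. Statements on the series, on what has been measured and on what is new or still open speak of the compounds shown alone.

Compound 2 `O=C(O)Cc1sc(Cc2ccccc2)nc1-c1ccc(Cl)cc1` is the reference point of this set. In an in vitro functional assay on HEK285-7 cells for antagonist activity at prostaglandin D2 receptor 2 (Homo sapiens), read by BRET and beta-arrestin recruitment (on this read-out higher numbers stand for larger maximal responses and lower numbers for smaller maximal responses), compound 2 gives 50%. Compound 1 `O=C(O)Cc1sc(Cc2ccccc2-c2ccccc2)nc1-c1ccc(Cl)cc1` carries an extra phenyl on an aromatic carbon, and in this assay compound 1 gives 50%. Compound 3 `O=C(O)Cc1sc(CSc2ccccc2)nc1-c1ccc(Cl)cc1` carries phenylsulfanyl in place of phenyl on the saturated chain carbon, and in this assay compound 3 gives 50%. The two single-point steps, no change at the digits printed from compound 1 to compound 2 (within the scatter) and no change at the digits printed from compound 2 to compound 3 (within the scatter), both leave the maximal response flat, so compound 2 stands level with compounds 1 and 3 on the numbers in hand.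

Compound 4 `O=C(O)Cc1sc(C(c2ccccc2)c2ccccn2)nc1-c1ccc(Cl)cc1` has not been measured. It differs from compound 2 by pyridin-2-yl in place of hydrogen on a saturated chain carbon bound to two aromatic carbons. The two measured steps are the nearest guides: one removes a phenyl from an aromatic carbon, the other swaps the group on the saturated chain carbon, and neither moves the read-out. Three compounds at one level give no sign that the maximal response answers to change in this part of the structure, though nothing measured puts a second group on that carbon. The step from compound 2 to compound 4 is therefore expected to be small, no change at the digits printed from compound 2 to compound 4 (within the scatter), with no clear direction. Compound 4 is expected to give 50% in this assay, within a range of 35% to 65%.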

Compound 4, largest response reached (reported as efficacy), in percent of the reference or control that the assay uses: 55%
Beside the measured number, compound 4's estimate is 5 percentage points below it; the measured number falls inside the stated range.
By their numbers in this assay, from the lowest: compounds 1, 2, 3 and 4 (each within the scatter of the next).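

In this assay, pyridin-2-yl in place of hydrogen on a saturated chain carbon bound to two aromatic carbons gives a number 5 percentage points higher from compound 2 to compound 4 (within the scatter). Compound 4 is the first compound shown with a second group on this carbon, so the flat picture from compounds 1, 2 and 3 now also covers a carbon that bears both phenyl and an added six-membered aromatic ring with a hetero atom, and none of the four compounds goes against it. No experimental finding on hand accounts for this flat maximal response, and the four values alone cannot tell whether either ring on this carbon matters to it.

Going by these compounds, it remains open whether the read-out stays at this level with a different kind of second group on the same carbon, such as an amine, a carboxylic acid, a methyl group or a longer chain. Also open, on these data alone, is whether pyridin-3-yl or pyridin-4-yl in place of pyridin-2-yl would stay within the scatter of compound 2, and whether replacing the phenyl of compound 4 with a second pyridin-2-yl would do the same.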